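This account rests on a few compounds, and the source may have more. Where it says the series, first, only, none or still open, it means among the compounds named here.

In a functional assay on HepG2 cells (Homo sapiens) for antiproliferative activity, read by MTT assay, with a stated time of 24 h (on this read-out higher numbers stand for weaker inhibition and lower numbers for stronger inhibition), compound 1 `COc1cc(OC)c(-c2coc3cc(OCC=C(C)C)ccc3c2=O)cc1OC` gives 280 nM. Compound 2 `COc1cc(OC)c(-c2coc3cc(OCC(=O)c4cccc(C(F)(F)F)c4)ccc3c2=O)cc1OC` reads > 10000 nM, which is a limit of the assay. Compound 3 `COc1cc(OC)c(-c2coc3cc(OCc4ccccc4C#N)ccc3c2=O)cc1OC` reads > 10000 nM, which is also a limit and not a number. Compound 3 thus stands at the limit of > 10000 nM in this assay, at which 2 of the 3 values shown sit.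

With (3-(trifluoromethyl)phenyl)carbonyl in place of 2-methylprop-1-en-1-yl, the series shows an at least 35-fold higher number from compound 1 to compound 2 (1.55 log units; beyond the scatter). With 2-cyanophenyl in the same place, it shows an at least 35-fold higher number from compound 1 to compound 3 (1.55 log units; beyond the scatter). Both steps are large, while the two limits give a step that the two limits leave unreadable from compound 2 to compound 3.

Compound 4 `COc1cc(OC)c(-c2coc3cc(OCc4cccc(Br)c4)ccc3c2=O)cc1OC`, not yet measured, carries 3-bromophenyl in place of 2-cyanophenyl on a saturated chain carbon bound to an oxygen on an aromatic ring. Among the compounds with values here, no measured step exchanges one substituted phenyl for another with a readable size, so the closest evidence is the loss seen in an at least 35-fold higher number from compound 1 to compound 3 (1.55 log units; beyond the scatter). Compound 4 also lacks 2-methylprop-1-en-1-yl, so it is expected to stay close to compound 3 in this assay, with no step beyond the scatter and quite possibly only a limit reported. The expected step is a number no higher from compound 3 to compound 4 (the limit leaves the size open). For compound 4 the estimated value is 10000 nM, with an expected range from 2500 nM to 40000 nM.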

Compound 4, half-maximal inhibitory concentration: 870 nM
Estimate against measurement, compound 4: 11-fold (1.06 log units) above, outside the stated range (below it).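

In this assay, the position on a saturated chain carbon bound to an oxygen on an aromatic ring turns out to tolerate at least one substituted phenyl: 3-bromophenyl gives an at least 11-fold lower number from compound 3 to compound 4 (1.06 log units; beyond the scatter) when it replaces 2-cyanophenyl, and an at least 11-fold lower number from compound 2 to compound 4 (1.06 log units; beyond the scatter) when it replaces (3-(trifluoromethyl)phenyl)carbonyl. The earlier loss therefore does not come with every replacement of 2-methylprop-1-en-1-yl, as the change to 3-bromophenyl leaves only a modest step, a 3.1-fold higher number from compound 1 to compound 4 (0.49 log units; beyond the scatter), although that step is still beyond the scatter. Compound 2 and compound 3 each stand at a limit of the assay and not at a number, so the two large steps give only a minimum size: the limit of > 10000 nM in this assay, at which 2 of the 4 values shown sit.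

The change from 2-cyanophenyl to 3-bromophenyl alters the substituent and its place on the ring together, so the compounds shown cannot separate the two, a question that 2-bromophenyl or 3-cyanophenyl would address. They also leave open how an unsubstituted benzyl, or a chain ending in an amine, would read at this position.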